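The source may report more compounds than this note shows. Statements on the series, on what has been measured and on what is new or still open speak of the compounds shown alone.

Measured so far in a functional assay on MCF7 cells (Homo sapiens) for antiproliferative activity, read by MTT assay, with a stated time of 72 h; on this read-out higher numbers stand for weaker inhibition and lower numbers for stronger inhibition:
- compound 1 `CCCSc1nc(N/N=C/c2ccc(Cl)cc2)c2nnn(Cc3ccccc3)c2n1` — a limit, > 64000 nM
- compound 2 `CCCSc1nc(N/N=C/c2ccc([N+](=O)[O-])cc2)c2nnn(Cc3ccccc3)c2n1` — 11000 nM
- compound 3 `CCCSc1nc(N/N=C/c2ccc3ccccc3c2)c2nnn(Cc3ccccc3)c2n1` — a limit, > 64000 nM

Compound 1 stands at the limit of this assay, and the value given for it is a limit rather than a number. The same holds for compound 3, as the limit of > 64000 nM in this assay, at which 2 of the 3 values shown sit, records. Only compound 2 returns a number; the move from chloro to nitro gives an at least 5.8-fold lower number from compound 1 to compound 2 (0.76 log units; beyond the scatter), and the move on to naphthalen-2-yl gives an at least 5.8-fold higher number from compound 2 to compound 3 (0.76 log units; beyond the scatter), while a step that the two limits leave unreadable from compound 1 to compound 3 cannot be sized because both ends are limits.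

Compound 4 `CCCSc1nc(N/N=C(\C)c2ccc(Br)cc2)c2nnn(Cc3ccccc3)c2n1` has not been measured. Against compound 1 the change is a group of 10 heavy atoms (8 carbon, 1 nitrogen, 1 bromine; one six-membered aromatic ring of carbon only) in place of a group of 9 heavy atoms (7 carbon, 1 nitrogen, 1 chlorine; one six-membered aromatic ring of carbon only), on a nitrogen on an aromatic ring. Within the data shown here, no measured step touches a halogen swap or the added methyl on the carbon with a double bond to nitrogen; the only step that lowered the number, that from compound 1 to compound 2, brought in nitro, which compound 4 lacks. Compound 4 is therefore expected to stay near compound 1, with a step that the limit leaves unreadable from compound 1 to compound 4 not beyond the scatter. The estimate for compound 4 in this assay is 80000 nM, within 30000 nM to 200000 nM, most likely again reported only as a limit.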

Compound 4, half-maximal inhibitory concentration: 13000 nM
Beside the measured number, compound 4's estimate is 6.2-fold (0.79 log units) above it; the measured number lies below the stated range.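

In this assay, exchanging the group on the nitrogen on an aromatic ring gives an at least 4.9-fold lower number from compound 1 to compound 4 (0.69 log units; beyond the scatter). Among these compounds, compound 2 no longer stands alone in returning a number, and compound 4 does so without nitro, so nitro is not the only group at this place that gives a number. Compound 1 and compound 3 remain limits rather than numbers: the limit of > 64000 nM in this assay, at which 2 of the 4 values shown sit.

The exchange brings in bromine for chlorine together with the added methyl on the carbon with a double bond to nitrogen, and no compound shown separates the two, so the step cannot be assigned to either. Also open, as far as these compounds go, is how an amine or a carboxylic acid in place of the halogen would read in this assay.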